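Aryl variation on the ring amine: working notes

The compounds below may be only part of what the source reports. "The series", "measured", "known", "first", "only" and "open" are said of these compounds alone.

Measured so far in a functional assay on CHO cells with adenosine receptor A1 (Homo sapiens) as the target, read by cAMP accumulation and immunoassay, with a stated time of 6 min, tested at 0.01 uM; a higher number here means a weaker effect of the compound at the concentration tested, a lower number a stronger effect:
compound 1 `Nc1scc(CN2CCN(c3cc(Cl)cc(Cl)c3)CC2)c1C(=O)c1ccc(Cl)cc1`: -1%
compound 2 `Nc1scc(CN2CCN(c3ccc(F)cc3Cl)CC2)c1C(=O)c1ccc(Cl)cc1`: 6.1%
compound 3 `Nc1scc(CN2CCN(c3ccc(OC(F)(F)F)cc3)CC2)c1C(=O)c1ccc(Cl)cc1`: 0%

All three numbers sit close to zero. Compound 2 has the highest of the three, but the step of a number 7.1 percentage points higher from compound 1 to compound 2 (within the scatter) and the step of a number 6.1 percentage points lower from compound 2 to compound 3 (within the scatter) are both within the scatter, as is a number 1 percentage points higher from compound 1 to compound 3 (within the scatter), so the three compounds are not separated by this assay at the concentration tested. Exchanging the aryl group on the amine nitrogen in the ring, whether by moving or adding chlorine or by bringing in trifluoromethoxy, has so far produced nothing beyond noise.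

Compound 4 `Nc1scc(CN2CCN(c3ccccc3F)CC2)c1C(=O)c1ccc(Cl)cc1` is not yet measured. It differs from compound 2 as follows: 2-fluorophenyl in place of 2-chloro-4-fluorophenyl on an amine nitrogen in a ring. The change removes one chlorine from the aryl group and keeps one fluorine. Among the measured compounds shown here, the steps that bear on it are the three aryl exchanges already seen, all within the scatter; none of them gives grounds to expect a step beyond the scatter here either, in either direction. Compound 4 is therefore expected to give 2% in this assay, with a range from -8% to 12%. The expected step from compound 2 to compound 4 is a number 4.1 percentage points lower from compound 2 to compound 4 (within the scatter).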

Compound 4, a percentage reported as activity, at one concentration (the size of the read-out at that concentration, not a potency): 2.1%
Compound 4: middle estimate off by 0.1 percentage points, on the low side; low and high end bracket the measured number.
By their numbers in this assay, from the lowest: compounds 1, 3, 4 and 2 (each within the scatter of the next).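

Taking chlorine off the 2-chloro-4-fluorophenyl group, with no new substituent entering, gives a number 4 percentage points lower from compound 2 to compound 4 (within the scatter) in this assay and so does not separate the two compounds. The 2-fluorophenyl group is likewise not separated from the other two aryl groups, with a number 2.1 percentage points higher from compound 3 to compound 4 (within the scatter) and a number 3.1 percentage points higher from compound 1 to compound 4 (within the scatter) in the same read-out, so the four aryl groups on this amine nitrogen now give one indistinguishable set of numbers, and the simple removal of a chlorine joins the exchanges that produce nothing beyond noise. Nothing at hand gives a reason for this flat outcome at the position.

Going by these compounds, whether a carboxylic acid or a primary amine on the phenyl ring, or a benzyl group in place of the aryl group on the nitrogen, would produce a step beyond the scatter stays open. Because each number is a read-out at a single concentration and not a potency, any differences among these four compounds that might appear at lower concentrations also remain unresolved.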